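Two limits, one unreadable step, a dichlorophenyl substitution

A few compounds are considered here, and "the series" means these few. Any claim that something is new, unique, unknown or untested is made for them only; others in the source may bear on it.

Compound 1 `O=[N+]([O-])c1cc(CSc2nnc(-c3ccccc3)n2C2CCCCC2)cc([N+](=O)[O-])c1`: in an ADME assay on HepG2 cells (Homo sapiens) for cytotoxicity, with a stated time of 48 h (a lower number here means a stronger inhibitor, a higher number a weaker inhibitor), compound 1 gives > 30000 nM, a limit of the assay.
Compound 2 `COc1ccc(Cn2c(SCc3cc([N+](=O)[O-])cc([N+](=O)[O-])c3)nnc2-c2ccccc2)cc1`: in this assay compound 2 gives > 30000 nM, also a limit.

Compound 2 therefore stands at the limit, where both measured values sit (the limit of > 30000 nM in this assay, at which 2 of the 2 values shown sit). Within the data shown here, the single measured step, a step that the two limits leave unreadable from compound 1 to compound 2, is left unreadable by the two limits. Compound 3 `O=[N+]([O-])c1cc(CSc2nnc(-c3ccccc3)n2-c2ccc(Cl)c(Cl)c2)cc([N+](=O)[O-])c1` differs from compound 2 by 3,4-dichlorophenyl in place of 4-methoxybenzyl on an aromatic nitrogen. No readable step bears on this change, so in this assay the writer expects no shift beyond the scatter and most likely another limit. Compound 3 is thus estimated at 40000 nM, within 15000 nM to 120000 nM. The expected step is a step that the limit leaves unreadable from compound 2 to compound 3.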

Compound 3, half-maximal inhibitory concentration: > 30000 nM
Compound 3 was reported as a limit (the forecaster's own chance of this, stated with the estimate: 80%); the middle value does not contradict the limit.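

The steps among compound 1, compound 2 and compound 3 cannot be read, since all three stand at one limit: the limit of > 30000 nM in this assay, at which 3 of the 3 values shown sit.

The compounds shown leave open how the group on the aromatic nitrogen affects the true values in this assay, all of which remain hidden behind that limit.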